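Methyl on the Amide Nitrogen of Compound 3

The source may hold more compounds than are shown below. What is called first, only, known or untested is meant among the compounds shown, and "the series" means these compounds.

Compound 1, `N#Cc1cnc(NCc2cnccc2C(F)(F)F)cc1N[C@H]1CC[C@H](O)CC1`: 350 nM in an assay on isolated protein for inhibition of protein kinase C theta type (Homo sapiens), read by TR-FRET, with a stated time of 2 h; on this read-out lower numbers stand for stronger inhibition and higher numbers for weaker inhibition
Compound 2, `N#Cc1cnc(NCc2cnccc2C(F)(F)F)cc1NCC1CCOCC1`: 400 nM in this assay
Compound 3, `N#Cc1cnc(NCc2cnccc2C(F)(F)F)cc1N[C@H]1CC[C@@H](C(N)=O)CC1`: 7 nM in this assay

Compound 3 stands at the lowest number of the three, and both of its neighbours sit far away: a 50-fold lower number from compound 1 to compound 3 (1.70 log units; beyond the scatter) and a 57-fold lower number from compound 2 to compound 3 (1.76 log units; beyond the scatter). Compound 1 and compound 2 lie close together, as a 1.1-fold higher number from compound 1 to compound 2 (0.06 log units; within the scatter) shows.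

Compound 4, `CNC(=O)[C@H]1CC[C@@H](Nc2cc(NCc3cnccc3C(F)(F)F)ncc2C#N)CC1`, keeps everything of compound 3 and changes only one spot: methyl in place of hydrogen on an amide-type nitrogen. Going by the values given here, no measured step touches this nitrogen. The two large steps concern the arrival of the whole carbamoyl group on the ring, not what sits on its nitrogen, so they give no direct guide to the size of this change. With the carbamoyl group kept and only a methyl added, the expectation is a modest shift, most likely towards a somewhat higher number, within or just beyond the scatter: a 2.1-fold higher number from compound 3 to compound 4 (0.33 log units; beyond the scatter). Compound 4 is therefore estimated at 15 nM in this assay, with a range from 4 nM to 60 nM.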

Compound 4, half-maximal inhibitory concentration: 27 nM
Beside the measured number, compound 4's estimate is 1.8-fold (0.26 log units) below it; measured number inside the range.
By their numbers in this assay, from the lowest: compound 3; then compound 4; then compounds 1 and 2 (each within the scatter of the next).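

In this assay the amide nitrogen turns out to be sensitive to even a single added methyl (a 3.9-fold higher number from compound 3 to compound 4 (0.59 log units; beyond the scatter)), so the amide hydrogen cannot be replaced by methyl without some loss. Most of the advantage of the amide-bearing side group nevertheless survives, as both remaining comparisons show (a 15-fold lower number from compound 2 to compound 4 (1.17 log units; beyond the scatter); a 13-fold lower number from compound 1 to compound 4 (1.11 log units; beyond the scatter)). No available evidence bears on what lies behind the loss on methylation.

The compounds shown leave open whether an ethyl group or a second methyl on this nitrogen would raise the number further or leave it unchanged. They also leave open whether the amide itself is needed, which a carboxylic acid or an aminomethyl group in its place would help to answer.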